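The compounds below may be only part of what the source reports. "The series", "measured", "known", "first", "only" and "open" are said of these compounds alone.

compound 1 `N#Cc1ccc(Cn2c(/C=C3\SC(=S)N(CC(=O)O)C3=O)nc3ccccc32)cc1` 16300 nM
compound 2 `O=C(O)CN1C(=O)/C(=C/c2nc3ccccc3n2Cc2ccc([N+](=O)[O-])cc2)SC1=S` 18600 nM
compound 3 `O=C(O)CN1C(=O)/C(=C/c2nc3ccccc3n2Cc2ccccc2)SC1=S` 22700 nM

All three numbers come from a functional assay on HeLa cells (Homo sapiens) for cytotoxicity, read by MTT assay, with a stated time of 48 h; on this read-out higher numbers stand for weaker inhibition and lower numbers for stronger inhibition. The compounds share one core and differ only in the group on the aromatic ring of the benzyl part. Compound 2, at 18600 nM, cannot be told apart from its two neighbours, as a 1.1-fold higher number from compound 1 to compound 2 (0.06 log units; within the scatter) and a 1.2-fold higher number from compound 2 to compound 3 (0.09 log units; within the scatter) show.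

The next compound to be tested is compound 4 `O=C(O)CN1C(=O)/C(=C/c2nc3ccccc3n2Cc2ccc(Cl)cc2)SC1=S`. It keeps everything in compound 2 except one group: chloro in place of nitro on an aromatic carbon. In words, this is chloro in place of nitro on an aromatic carbon, para to a large group, so a 4-nitrobenzyl becomes a 4-chlorobenzyl.

Among the compounds with values here, no measured step makes this exact swap, but three steps change the same place. Besides the two above, there is a 1.4-fold higher number from compound 1 to compound 3 (0.14 log units; within the scatter). Among nitro, cyano and hydrogen at this place, then, no change has moved the number beyond the scatter. Chloro is a new group here, so this is only a guide, but no step beyond the scatter is expected.

The expected result is a 1.0-fold lower number from compound 2 to compound 4 (0.01 log units; within the scatter).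

For compound 4 the estimated value is 18000 nM, with an expected range from 9000 nM to 36000 nM.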

Compound 4, half-maximal inhibitory concentration: 8720 nM
Compound 4: the middle estimate sits 2.1-fold (0.31 log units) above what was measured; measured number outside the range, below it.
By their numbers in this assay, from the lowest: compounds 4, 1, 2 and 3 (each within the scatter of the next, the first and the last beyond it).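

Within the data shown here, the place on the benzyl ring where all four compounds differ turns out not to be indifferent to its group, since in this assay chloro gives the first steps here that lie beyond the scatter, though both are modest: a 2.1-fold lower number from compound 2 to compound 4 (0.33 log units; beyond the scatter) and a 2.6-fold lower number from compound 3 to compound 4 (0.42 log units; beyond the scatter). The picture is not a clean ranking, however, as a 1.9-fold lower number from compound 1 to compound 4 (0.27 log units; within the scatter) stays within the scatter, so compound 4 separates from compound 2 and compound 3 but not from compound 1, while compound 1 itself cannot be told apart from compound 2 or compound 3. Nothing available explains why chloro behaves differently from nitro or hydrogen at this place.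

The compounds shown leave open whether this small gain belongs to chloro alone or would also appear with other groups at the same place, such as bromo, methoxy, an amine or a carboxylic acid. They also leave open whether chloro on another carbon of the ring would give the same step, and whether the step would hold in cells other than HeLa.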